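Swapping dimethylamino for methyl on the shared core

The compounds below may be only part of what the source reports. "The series", "measured", "known", "first", "only" and "open" are said of these compounds alone.

In a functional assay on Jurkat cells (Homo sapiens) for antiproliferative activity, read by MTT assay, with a stated time of 72 h (on this read-out higher numbers stand for weaker inhibition and lower numbers for stronger inhibition), compound 1 (`CNc1nc(-c2cc(OC)c(OC)c(OC)c2)c(-c2ccc(C)cc2)s1`) reads 19 nM while compound 2 (`COc1cc(-c2nc(N(C)C)sc2-c2ccc(C)cc2)cc(OC)c1OC`) reads 6660 nM and compound 3 (`CCOc1ccc(-c2sc(N(C)C)nc2-c2cc(OC)c(OC)c(OC)c2)cc1`) reads 4150 nM on the same scale. Compound 2 thus sits at the high end of these numbers, together with compound 3 and far from compound 1. Compound 4 (`COc1cc(-c2nc(C)sc2-c2ccc(C)cc2)cc(OC)c1OC`) has not yet been measured. It carries methyl in place of dimethylamino on an aromatic carbon of the shared core (methyl in place of dimethylamino on an aromatic carbon). The most relevant evidence is the large step of a 350-fold higher number from compound 1 to compound 2 (2.54 log units; beyond the scatter) for methyl in place of hydrogen on a nitrogen, which shows that the group at this place can move the number strongly. The step of a 1.6-fold lower number from compound 2 to compound 3 (0.21 log units; within the scatter) for ethoxy in place of methyl stays within the scatter and says little here. Neither step removes the dimethylamino group itself, so the size remains uncertain. A moderate move towards stronger inhibition is expected, estimated as a 6.7-fold lower number from compound 2 to compound 4 (0.82 log units; beyond the scatter) (this assay). For compound 4 the estimated value is 1000 nM (expected range 100 nM to 8000 nM).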

Compound 4, half-maximal inhibitory concentration: 517 nM
For compound 4 the middle estimate is 1.9-fold (0.29 log units) above the measured one; the range from low to high includes it.
By their numbers in this assay, from the lowest: compound 1; then compound 4; then compounds 3 and 2 (each within the scatter of the next).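

In this assay, the dimethylamino group proves not to be needed on this aromatic carbon of the shared core: methyl in its place gives a 13-fold lower number from compound 2 to compound 4 (1.11 log units; beyond the scatter), although methyl is the smaller group and has no hydrogen-bond acceptor. Methyl still does not recover the reading of the methylamino group, with a 27-fold higher number from compound 1 to compound 4 (1.43 log units; beyond the scatter), so the three groups at this place fall in the order methylamino, methyl, dimethylamino, with one nitrogen-bearing group at each end. No measurement at hand accounts for this order.

The compounds shown leave open how an unsubstituted amino group, a plain hydrogen or a longer chain such as ethyl would read at this carbon. They also leave open whether the ethoxy group of compound 3 would change as little alongside methyl as it does alongside dimethylamino.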